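Swapping methylsulfonyl for ethyl in compound 3

This account rests on a few compounds, and the source may have more. Where it says the series, first, only, none or still open, it means among the compounds named here.

Compound 3 `CS(=O)(=O)Cc1cn([C@H]2C[C@H](O)[C@@H](CO)O2)c(=O)[nH]c1=O` reads > 200000 nM in an ADME assay on L1210/0 cells (Mus musculus) for cytotoxicity, with a stated time of 48 h (on this read-out higher numbers stand for weaker inhibition and lower numbers for stronger inhibition), which is a limit of the assay and not a number. In this assay compound 1 `C=Cc1cn([C@H]2C[C@H](O)[C@@H](CO)O2)c(=O)[nH]c1=O` gives 14200 nM and compound 2 `C=C(Cl)c1cn([C@H]2C[C@H](O)[C@@H](CO)O2)c(=O)[nH]c1=O` gives 1660 nM. Compound 4 `CCCc1cn([C@H]2C[C@H](O)[C@@H](CO)O2)c(=O)[nH]c1=O` has ethyl in place of methylsulfonyl on a saturated chain carbon bound to an aromatic carbon. Going by the values given here, two measured steps bear on this: an at least 14-fold higher number from compound 1 to compound 3 (1.14 log units; beyond the scatter) and an at least 120-fold higher number from compound 2 to compound 3 (2.08 log units; beyond the scatter), both large and beyond the scatter. Compound 1 is the closer guide, since an 8.6-fold lower number from compound 1 to compound 2 (0.93 log units; beyond the scatter) brings in chloro, which compound 4 lacks. A large change towards a lower number is therefore expected, an at least 5.0-fold lower number from compound 3 to compound 4 (0.69 log units; beyond the scatter). The estimate for compound 4 is 40000 nM, with an expected range of 10000 nM to 150000 nM.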

Compound 4, half-maximal inhibitory concentration: > 200000 nM
Compound 4: no number, only a limit; the forecaster's own chance of this, stated with the estimate: 25%; middle value at least 5.0-fold (0.69 log units) away from the limit.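

In this assay compound 4 reads > 200000 nM, which is a limit of the assay and not a number. Its propyl chain stands well apart from the double-bonded chains, with an at least 14-fold higher number from compound 1 to compound 4 (1.14 log units; beyond the scatter) and an at least 120-fold higher number from compound 2 to compound 4 (2.08 log units; beyond the scatter), so among the four compounds shown only those with a double-bonded chain give a number. The step between compound 3 and compound 4 cannot be read, because both rest on the same limit: the limit of > 200000 nM in this assay, at which 2 of the 4 values shown sit.

Open, going by these compounds, is whether a triple-bonded ethynyl group on the aromatic carbon would also give a number. Also open, on these data alone, is whether a saturated chain carrying chloro or an amine would.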